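An Allyl to Propargyl Exchange at a Level Baseline

The compounds below may be only part of what the source reports. "The series", "measured", "known", "first", "only" and "open" are said of these compounds alone.

In a functional assay on U-937 cells (Homo sapiens) for cytotoxicity, read by MTT assay, with a stated time of 24 h (a higher number here means a weaker inhibitor, a lower number a stronger inhibitor), compound 1 `BrCCCCOc1c(Br)cc(Br)cc1Oc1ccc(Br)cc1Br` gives 29 ug/mL. Compound 2 `C=CCOc1c(Br)cc(Br)cc1Oc1ccc(Br)cc1Br` gives 29 ug/mL, which places it level with compound 1 at the digits shown. Compound 3 `C#CCOc1c(Br)cc(Br)cc1Oc1ccc(Br)cc1Br` carries ethynyl in place of vinyl on a saturated chain carbon bound to an oxygen on an aromatic ring, the exchange of allyl to propargyl: ethynyl in place of vinyl on a saturated chain carbon bound to an oxygen on an aromatic ring. Within the data shown here, only one measured step bears on this, with vinyl in place of 3-bromopropyl at the same place, and it shows no change at the digits printed from compound 1 to compound 2 (within the scatter). On that single step, no change beyond the scatter is expected in this assay, and neither direction is favoured. The estimated step is a 1.1-fold lower number from compound 2 to compound 3 (0.03 log units; within the scatter). Compound 3 is expected at 27 ug/mL, with an estimated range of 14 ug/mL to 52 ug/mL.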

Compound 3, half-maximal inhibitory concentration: 29.5 ug/mL
For compound 3 the middle estimate is 1.1-fold (0.04 log units) below the measured one, and the stated range covers the measured number.
By their numbers in this assay, from the lowest: compounds 1, 2 and 3 (each within the scatter of the next).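

In this assay the exchange of allyl to propargyl reads as a 1.0-fold higher number from compound 2 to compound 3 (0.01 log units; within the scatter) and stays level, and ethynyl in place of 3-bromopropyl reads as a 1.0-fold higher number from compound 1 to compound 3 (0.01 log units; within the scatter) and does the same. The earlier pair had set vinyl against 3-bromopropyl; a triple bond now joins them on a saturated chain carbon bound to an oxygen on an aromatic ring, and the three compounds cannot be told apart at this place. Nothing available gives a reason for this flat result.

From the compounds shown here alone, whether this place stays as flat with an amine or a carboxylic acid on the chain remains open. So does whether a longer chain, or a hydroxyl in place of the whole ether, would move the number away from this level.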